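Compound 3 and the amide change to compound 4

The source may report more compounds than this note shows. Statements on the series, on what has been measured and on what is new or still open speak of the compounds shown alone.

Measured in a functional assay on L6 cells (Rattus norvegicus) for inhibition; on this read-out higher numbers stand for weaker inhibition and lower numbers for stronger inhibition
compound 1 `Cc1ccc(CNC(=O)c2nn(-c3ccc(F)cc3)c(CC[C@@H](O)C[C@@H](O)CC(=O)O)c2C(C)C)cc1` gives 800 nM
compound 2 `CC(C)c1c(C(=O)N2CCC[C@H](c3ccccc3)C2)nn(-c2ccc(F)cc2)c1CC[C@@H](O)C[C@@H](O)CC(=O)O` gives 310 nM
compound 3 `CCN(Cc1ccccc1)C(=O)c1nn(-c2ccc(F)cc2)c(OC[C@@H](O)C[C@@H](O)CC(=O)O)c1C(C)C` gives 2660 nM

Compound 3 has the highest number of the three, so it is the weakest inhibitor here. Compound 4 `Cc1cccc(CNC(=O)c2nn(-c3ccc(F)cc3)c(OC[C@@H](O)C[C@@H](O)CC(=O)O)c2C(C)C)c1` differs from it only on a carbonyl carbon (3-methylbenzyl)amino in place of benzyl(ethyl)amino on a carbonyl carbon and this is the change followed here. The nearest measured evidence is a 2.6-fold lower number from compound 1 to compound 2 (0.41 log units; beyond the scatter) where 3-phenylpiperidin-1-yl replaced (4-methylbenzyl)amino. The present change runs roughly the opposite way, on a different core, so it is only a loose guide. A slightly higher number is therefore expected in this assay and the expected step is a 1.5-fold higher number from compound 3 to compound 4 (0.18 log units; within the scatter) which may stay within the scatter. For compound 4 the estimated value is 4000 nM with an expected range of 1300 nM to 12000 nM as the likely span.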

Compound 4, half-maximal inhibitory concentration: 280 nM
Compound 4: middle estimate off by 14-fold (1.15 log units), on the high side; measured number outside the range, below it.
By their numbers in this assay, from the lowest: compounds 4 and 2 (each within the scatter of the next); then compound 1; then compound 3.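

Swapping benzyl(ethyl)amino for (3-methylbenzyl)amino on the carbonyl carbon gives a 9.5-fold lower number from compound 3 to compound 4 (0.98 log units; beyond the scatter) in this assay, so this position can move the number substantially on this core. The entering group brings an amide hydrogen, whereas the earlier step to compound 2 removed one and the number still fell, so gaining or losing that hydrogen does not set the direction across these two cores. Nothing measured here accounts for the step. From the compounds shown here alone, it remains open whether the methyl group, the lost ethyl or the gained amide hydrogen matters most. A plain benzylamino group on this carbonyl carbon would help separate them.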